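Cycloalkylamino series: Vero cytotoxicity working notes

The compounds below may be only part of what the source reports. "The series", "measured", "known", "first", "only" and "open" are said of these compounds alone.

Compound 1 `[O-][n+]1nc(NC2CCC2)[n+]([O-])c2ccc(F)cc21` is the reference point of the set. In an ADME assay on Vero cells (Chlorocebus sabaeus) for cytotoxicity, read by CellTiter-Glo, with a stated time of 72 h (a lower number here means that less compound is tolerated, a higher number that more compound is tolerated), compound 1 gives 1.6 ug/mL. Compound 2 `[O-][n+]1nc(NC2CCCC2)[n+]([O-])c2ccc(F)cc21` differs from compound 1 by cyclopentyl in place of cyclobutyl on a nitrogen on an aromatic ring; in this assay compound 2 gives 2.3 ug/mL, a step of a 1.4-fold higher number from compound 1 to compound 2 (0.16 log units; within the scatter). Compound 3 `[O-][n+]1nc(NC2CCC2)[n+]([O-])c2ccc(Br)cc21` differs from compound 1 by bromo in place of fluoro on an aromatic carbon, and this is also the whole difference between the core shared by compound 3 and compound 4 and the core shared by compound 1 and compound 2. In this assay compound 3 gives 3.8 ug/mL, a step of a 2.4-fold higher number from compound 1 to compound 3 (0.38 log units; beyond the scatter). Compound 3 has the highest number of the three measured, but its gap to compound 2 lies within the scatter, so no order between compound 2 and compound 3 is read from these numbers.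

Compound 4 `[O-][n+]1nc(NC2CCCC2)[n+]([O-])c2ccc(Br)cc21` is not yet measured. It differs from compound 3 by cyclopentyl in place of cyclobutyl on a nitrogen on an aromatic ring. This is the same change as that from compound 1 to compound 2, occurring twice among the compounds shown, and the place is described in identical words for both pairs, so it is treated as the same change on a core that differs only as noted. Because the earlier instance gave a 1.4-fold higher number from compound 1 to compound 2 (0.16 log units; within the scatter), a step within the scatter, the expected step in this assay is a 1.4-fold higher number from compound 3 to compound 4 (0.14 log units; within the scatter), with no reason from the data to expect a larger move. Compound 4 is therefore estimated at 5.3 ug/mL in this assay. The range expected for compound 4 runs from 2.7 ug/mL to 10 ug/mL.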

Compound 4, half-maximal cytotoxic concentration: 18 ug/mL
For compound 4 the middle estimate is 3.4-fold (0.53 log units) below the measured one; measured number outside the range, above it.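

On the core of compound 3, cyclopentyl in place of cyclobutyl gives a 4.7-fold higher number from compound 3 to compound 4 (0.68 log units; beyond the scatter) in this assay, and this step does not repeat the one seen on the core of compound 1: the same change on two cores in this assay, a 1.4-fold higher number (0.16 log units; within the scatter) from compound 1 to compound 2 and a 4.7-fold higher number (0.68 log units; beyond the scatter) from compound 3 to compound 4, 3.3-fold (0.52 log units) apart, beyond the scatter of two such steps

Read along the other edge of the same set, bromo in place of fluoro gives a 7.8-fold higher number from compound 2 to compound 4 (0.89 log units; beyond the scatter), and this step likewise depends on the group on the nitrogen: the same change on two cores in this assay, a 2.4-fold higher number (0.38 log units; beyond the scatter) from compound 1 to compound 3 and a 7.8-fold higher number (0.89 log units; beyond the scatter) from compound 2 to compound 4, 3.3-fold (0.52 log units) apart, beyond the scatter of two such steps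

Both comparisons rest on the same compounds, so they are a single observation seen from two sides: in this assay the two changes do not add, and a step measured on one core cannot be carried to the other at face value, but nothing here shows why this happens or whether it holds on any other core.

The compounds shown leave open whether a larger ring such as cyclohexyl, or an open chain such as isopropyl, on the nitrogen would continue the move to a higher number with bromo on the aromatic carbon. They also leave open whether chloro on that carbon would follow the pattern of fluoro or that of bromo.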